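The compounds below may be only part of what the source reports. "The series", "measured", "known", "first", "only" and "open" are said of these compounds alone.

Of the compounds shown here, three have been tested for their ability to slow the growth of a human liver cancer cell line, and a fourth is to be put through the same test. Compound 1 is `COc1ccc(/C=C/C(=O)c2ccccc2-c2ccc(F)cc2)cc1`; in a functional assay on HepG2 cells (Homo sapiens) for antiproliferative activity, read by sulforhodamine B assay, with a stated time of 48 h (on this read-out lower numbers stand for stronger inhibition and higher numbers for weaker inhibition), compound 1 gives 93 nM. Compound 2 is `COc1ccc(/C=C/C(=O)c2ccccc2-c2ccc(F)nc2)cc1`, and in this assay compound 2 gives 290 nM. The change from compound 1 to compound 2 is 6-fluoropyridin-3-yl in place of 4-fluorophenyl on an aromatic carbon, and it brought a 3.1-fold higher number from compound 1 to compound 2 (0.49 log units; beyond the scatter).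

Compound 3 is `COc1ccc(C(=O)/C=C/c2ccccc2-c2ccc(F)cc2)cc1OC`. It is built on a different core from compound 1, and the difference between the two cores is not broken down here. In this assay compound 3 gives 6600 nM, the highest of the three numbers and far beyond the scatter from both compound 1 and compound 2.

Compound 4 is `COc1ccc(C(=O)/C=C/c2ccccc2-c2ccc(F)nc2)cc1OC`, and it has not yet been measured in this assay. The change from compound 3 to compound 4 is 6-fluoropyridin-3-yl in place of 4-fluorophenyl on an aromatic carbon; the group leaving, the group entering and the place are the same as in the change from compound 1 to compound 2, so this is the same change, seen for a second time, now on the core of compound 3. Among the compounds with values here, the only guide to its size is the one earlier instance, a 3.1-fold higher number from compound 1 to compound 2 (0.49 log units; beyond the scatter), and the expectation for compound 4 rests on that single step together with the number for compound 3. On that basis the step from compound 3 to compound 4 is estimated as a 2.7-fold higher number from compound 3 to compound 4 (0.44 log units; beyond the scatter), and compound 4 is expected to give about 18000 nM, most likely between 6000 nM and 50000 nM.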

Compound 4, half-maximal inhibitory concentration: 17000 nM
Compound 4: the middle estimate sits 1.1-fold (0.02 log units) above what was measured, and the stated range covers the measured number.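

In this assay, putting 6-fluoropyridin-3-yl in place of 4-fluorophenyl brought a 2.6-fold higher number from compound 3 to compound 4 (0.41 log units; beyond the scatter), and this second instance agrees in size with the first: the same change on two cores in this assay, a 3.1-fold higher number (0.49 log units; beyond the scatter) from compound 1 to compound 2 and a 2.6-fold higher number (0.41 log units; beyond the scatter) from compound 3 to compound 4, 1.2-fold (0.08 log units) apart, within the scatter of two such steps On these two cores, then, the change raised the number by a similar amount, so its size on one core was a fair guide to its size on the other, even though the two cores are built differently. This does not show that the change would behave the same way on a third core or in another cell line, as two instances in a single assay are a small base, and the numbers alone do not say why the swap weakens inhibition.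

The compounds shown leave open how other groups on this aromatic carbon would fare, such as 4-chlorophenyl, 6-methoxypyridin-3-yl or a pyridine ring carrying an amine instead of the fluorine. They also leave open which of the features that separate the two cores accounts for the large gap between their numbers, a question that only compounds differing in one place at a time could settle.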